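A few compounds are considered here, and "the series" means these few. Any claim that something is new, unique, unknown or untested is made for them only; others in the source may bear on it.

Compound 3 `Cc1ccccc1Cc1nc2cc(O[C@H]3CC[C@@H](C(=O)O)CC3)ccc2n1C` gives 5400 nM in an assay on isolated protein for inhibition of Long-chain-fatty-acid--CoA ligase 1 (Mus musculus), read by mass spectrometry, with a stated time of 90 min, in the presence of a further agent that is not named here (a lower number here means a stronger inhibitor, a higher number a weaker inhibitor), the highest of the three numbers in hand. Its nearest neighbour is compound 2 `Cc1cccc(Cc2c(C(N)=O)c3cc(O[C@H]4CC[C@@H](C(=O)O)CC4)ccc3n2C)c1`, which gives 440 nM in this assay; furthest is compound 1 `Cc1cccc(Cc2nc3cc(O[C@H]4CC[C@@H](C(=O)O)CC4)ccc3n2C)c1`, which gives 30 nM. Within the data shown here, the only measured step reaching compound 3 is a 180-fold higher number from compound 1 to compound 3 (2.26 log units; beyond the scatter), a large rise. Compound 4 `Cn1c(Cc2cccc(C#N)c2)nc2cc(O[C@H]3CC[C@@H](C(=O)O)CC3)ccc21` is not yet measured; it differs from compound 3 by 3-cyanophenyl in place of 2-methylphenyl on a saturated chain carbon bound to an aromatic carbon. Among the measured compounds shown here, no measured pair covers a nitrile, but the 3-cyanophenyl matches the 3-methylphenyl of compound 1, whose step a 180-fold higher number from compound 1 to compound 3 (2.26 log units; beyond the scatter) ran the opposite way. The expected step is therefore a large fall, a 90-fold lower number from compound 3 to compound 4 (1.95 log units; beyond the scatter). For compound 4 the estimate is 60 nM, within 15 nM to 300 nM.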

Compound 4, half-maximal inhibitory concentration: 22000 nM
Compound 4: the middle estimate sits 370-fold (2.56 log units) below what was measured; measured number above the stated range.
By their numbers in this assay, from the lowest: compound 1; then compound 2; then compound 3; then compound 4.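

Cyano in place of methyl on an aromatic carbon brings [ a 730-fold higher number from compound 1 to compound 4 (2.87 log units; beyond the scatter) ], so the strength seen with 3-methylphenyl does not carry over to 3-cyanophenyl, although the two groups sit in the same place. 3-Cyanophenyl in place of 2-methylphenyl also gives [ a 4.1-fold higher number from compound 3 to compound 4 (0.61 log units; beyond the scatter) ], which puts this change below even the weak 2-methylphenyl. No measurement on hand accounts for either step.

The compounds shown leave open whether other groups in that place, such as chloro, methoxy or ethyl, would hold the number near that of 3-methylphenyl. They also leave open whether 2-cyanophenyl would rise as far as 2-methylphenyl did.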